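Growing the Ring on the Carbonyl Carbon

The source may report more compounds than this note shows. Statements on the series, on what has been measured and on what is new or still open speak of the compounds shown alone.

For the measured compounds named here, compound 3, `COc1ccc(N)c(C2=NN(C(=O)C3CCCC3)C(C)(C)S2)c1`, is tested in an assay on isolated protein for inhibition of Nitric oxide synthase, inducible (Homo sapiens), read by scintillation counting, with a stated time of 30 min, tested at 50 uM (a lower number here means less inhibition, a higher number more inhibition at the concentration tested (going by the name of the read-out)), and gives 65%, the lowest of the three numbers measured so far. Its two companions share the same core and differ from it only in the group on the carbonyl carbon. Compound 1, `CCCCC(=O)N1N=C(c2cc(OC)ccc2N)SC1(C)C`, carries a butyl there and gives 101%. Compound 2, `COc1ccc(N)c(C2=NN(C(=O)C3CC3)C(C)(C)S2)c1`, carries a cyclopropyl and gives 90.1%. Every step between these three lies beyond the scatter: a number 10.9 percentage points lower from compound 1 to compound 2 (beyond the scatter), a number 36 percentage points lower from compound 1 to compound 3 (beyond the scatter) and a number 25.1 percentage points lower from compound 2 to compound 3 (beyond the scatter). Within this small set, the number falls as the ring on the carbonyl carbon grows from three members to five.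

Compound 4, `COc1ccc(N)c(C2=NN(C(=O)C3CCCCC3)C(C)(C)S2)c1`, has not yet been measured. It differs from compound 3 in one place: cyclohexyl in place of cyclopentyl on a carbonyl carbon.

The step that bears most directly on this change is a number 25.1 percentage points lower from compound 2 to compound 3 (beyond the scatter), where the ring on the carbonyl carbon grew by two members and the number fell by a modest amount. The move from cyclopentyl to cyclohexyl is a smaller enlargement of the same kind, so a further downward step beyond the scatter is expected, though it may be smaller. Compound 4 is therefore expected to give about 45%, with a range from 20% to 68%. That estimate corresponds to an expected step of a number 20 percentage points lower from compound 3 to compound 4 (beyond the scatter).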

Compound 4, a percentage reported as inhibition, at one concentration (the size of the read-out at that concentration, not a potency): 100%
Beside the measured number, compound 4's estimate is 55 percentage points below it; measured number above the stated range.
By their numbers in this assay, from the lowest: compound 3; then compounds 2, 4 and 1 (each within the scatter of the next, the first and the last beyond it).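

The fall in the number as the ring on the carbonyl carbon grew does not continue: going from the five-membered to the six-membered ring in this assay gives a number 35 percentage points higher from compound 3 to compound 4 (beyond the scatter), a large step for so small a change. Compound 4 also lands level with both other companions, with a number 9.9 percentage points higher from compound 2 to compound 4 (within the scatter) and a number 1 percentage points lower from compound 1 to compound 4 (within the scatter), so cyclopentyl alone stands apart among these groups, and ring size gives no steady trend across the cyclopropyl, cyclopentyl and cyclohexyl compounds. Nothing at hand explains why the cyclopentyl compound differs from the others.

The compounds shown leave open whether this dip is a narrow feature of cyclopentyl or part of a wider pattern, which a cyclobutyl or cycloheptyl ring, a phenyl ring or a tetrahydropyranyl ring with its ring oxygen could help to settle. Each number also comes from a single concentration, so how the potencies of these compounds compare remains open.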